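Gut microsome clearance across a shared core: three measured, one pending

The source may hold more compounds than are shown below. What is called first, only, known or untested is meant among the compounds shown, and "the series" means these compounds.

Measured so far:
compound 1 `COc1ccc(OC(F)(F)F)cc1Cn1c(C(=O)NCC(C)(C)CO)cc2cc(C#N)ccc21` < 6 mL.min-1.g-1
compound 2 `CCOc1ccc(OC(F)(F)F)cc1Cn1c(C(=O)NCC(C)(C)CO)cc2cc(C#N)ccc21` < 6 mL.min-1.g-1
compound 3 `CC(C)(O)CCNC(=O)c1cc2cc(C#N)ccc2n1Cc1cccc(OC(F)(F)F)c1` < 6 mL.min-1.g-1

In an in vitro ADME assay on microsomes from Gut (Homo sapiens) for metabolic stability, using NADPH (on this read-out higher numbers stand for fast clearance and lower numbers for slow clearance), compound 1 gives < 6 mL.min-1.g-1, a limit of the assay. Compound 2 gives < 6 mL.min-1.g-1, also a limit. Compound 3 gives < 6 mL.min-1.g-1, again a limit. All three sit at the limit of < 6 mL.min-1.g-1 in this assay, at which 3 of the 3 values shown sit. The change from compound 2 to compound 1, (hydrogen in place of methyl on a saturated chain carbon bound to an oxygen on an aromatic ring), gives a step that the two limits leave unreadable from compound 2 to compound 1. The difference between the cores of compound 2 and compound 3 is not broken down here.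

Compound 4 `CC(O)CCNC(=O)c1cc2cc(C#N)ccc2n1Cc1cccc(OC(F)(F)F)c1` is not yet measured. It differs from compound 3 by hydrogen in place of methyl on a saturated chain carbon bound to an oxygen on a saturated carbon and two saturated chain carbons, the same kind of change as from compound 2 to compound 1, though here the carbon is bound to an oxygen on a saturated carbon and two saturated chain carbons rather than to an oxygen on an aromatic ring.

The step from compound 3 to compound 4 is expected to be a step that the limit leaves unreadable from compound 3 to compound 4, resting on compound 3 sitting at the limit of < 6 mL.min-1.g-1 in this assay, at which 3 of the 3 values shown sit. Compound 4 is therefore expected near 4 mL.min-1.g-1, most likely reported again only as a limit, because compound 3 gives < 6 mL.min-1.g-1.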

Compound 4, intrinsic clearance in microsomes: < 6 mL.min-1.g-1
Compound 4: no number, only a limit (the forecaster's own chance of this, stated with the estimate: 85%); the middle value lies beyond the limit too.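

Compound 3 and compound 4 both give only limits of the assay, so no step can be read between them: (the limit of < 6 mL.min-1.g-1 in this assay, at which 4 of the 4 values shown sit). The compounds shown leave open how the change from 3-hydroxy-3-methylbutyl to 3-hydroxybutyl affects clearance in this assay above this limit.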